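A Pyrrole for a Pyridine on the Aryl Amide

A few compounds are considered here, and "the series" means these few. Any claim that something is new, unique, unknown or untested is made for them only; others in the source may bear on it.

Of the compounds shown here, two sharing a core have been measured in a functional assay on A-375 cells (Homo sapiens) for activation, with a stated time of 3 days; a higher number here means that more compound is needed for the effect, a lower number that less compound is needed. Compound 1 `O=C(Nc1ccc(-c2cscn2)cc1)C1CCCN(Cc2cc(F)cc(F)c2)C1` gives 1500 nM in this assay. Compound 2 `O=C(Nc1ccc(-c2cccnc2)cc1)C1CCCN(Cc2ccc(F)c(F)c2)C1` gives 1060 nM in this assay, the lower of the two numbers shown, although compound 1 lies within the usual scatter of it, so the two cannot be told apart. Compound 3 `O=C(Nc1ccc(-c2ccc[nH]2)cc1)C1CCCN(Cc2ccc(F)c(F)c2)C1` has not yet been measured. It differs from compound 2 in one place: 1H-pyrrol-2-yl in place of pyridin-3-yl on an aromatic carbon. Among the compounds with values here, no step between measured compounds bears on this change directly; the two measured values show only that exchanging one heteroaryl ring for another left the numbers within the scatter of each other. On that basis a step of modest size, if any, is expected. The estimate for compound 3 in this assay is 1500 nM, with a range from 400 nM to 5000 nM. This corresponds to an expected step of a 1.4-fold higher number from compound 2 to compound 3 (0.15 log units; within the scatter).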

Compound 3, half-maximal effective concentration: 720 nM
Beside the measured number, compound 3's estimate is 2.1-fold (0.32 log units) above it; low and high end bracket the measured number.
By their numbers in this assay, from the lowest: compounds 3, 2 and 1 (each within the scatter of the next, the first and the last beyond it).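

Within the data shown here, this is the first step that isolates a single place: in this assay, putting 1H-pyrrol-2-yl in place of pyridin-3-yl on an aromatic carbon, para to a large group, gives a 1.5-fold lower number from compound 2 to compound 3 (0.17 log units; within the scatter). For this pair, a six-membered aromatic ring with one hydrogen-bond acceptor and a five-membered aromatic ring with one hydrogen-bond donor cannot be told apart, so the exchange registers no change beyond the scatter. No measurement at hand explains this result or shows what either ring contributes.

The compounds shown leave open whether this position accepts a group of another kind, such as a morpholine or a carboxylic acid. They also leave open what would follow from a methyl group on the pyrrole nitrogen, or from a plain phenyl ring.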